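Bromo for 4-hydroxyphenyl on the shared core

The source may report more compounds than this note shows. Statements on the series, on what has been measured and on what is new or still open speak of the compounds shown alone.

compound 1 `COc1cccc(-c2cc(C)cn3c(CSCCc4ccccc4)cnc23)c1` — > 50 ug/mL, a limit of the assay
compound 2 `Cc1cc(-c2ccc(O)cc2)cn2c(CSCCc3ccccc3)cnc12` — > 50 ug/mL, a limit of the assay
compound 3 `Cc1cc(I)c2ncc(CSCCc3ccccc3)n2c1` — > 50 ug/mL, a limit of the assay

All three values come from an ADME assay on HEL cells (Homo sapiens) for cytotoxicity, with a stated time of 3 days; a lower number here means that less compound is tolerated, a higher number that more compound is tolerated. Compound 2 stands at a limit, not at a number. The two further values shown are limits as well, so no order among the three can be read. Compound 4 `Cc1cc(Br)cn2c(CSCCc3ccccc3)cnc12` carries bromo in place of 4-hydroxyphenyl on an aromatic carbon. For the measured compounds named here, the one measured step of related kind, a step that the two limits leave unreadable from compound 1 to compound 3, is itself unreadable, its two ends both being limits, so it gives no size. What the data show is the limit of > 50 ug/mL in this assay, at which 3 of the 3 values shown sit. No step beyond the scatter is therefore expected in this assay. Compound 4 is expected to give 80 ug/mL, within 40 ug/mL to 200 ug/mL, most likely again as a limit. The expected step is a step that the limit leaves unreadable from compound 2 to compound 4.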

Compound 4, half-maximal cytotoxic concentration: 28 ug/mL
Compound 4: the middle estimate sits 2.9-fold (0.46 log units) above what was measured; the whole stated range lies above it.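

For the compounds shown here, the first step with a readable floor is an at least 1.7-fold lower number from compound 2 to compound 4 (0.25 log units; that floor lies within the scatter) in this assay for bromo in place of 4-hydroxyphenyl. Compound 4 is the only compound shown that gives a number rather than a limit, so a change at this position can bring the value inside the range of the assay. The other compounds stay at that limit: the limit of > 50 ug/mL in this assay, at which 3 of the 4 values shown sit.

On these data alone, the full size of the step stays open, and its floor alone does not clear the scatter. Also open, as far as these compounds go, is how an amine or a carboxylic acid at this position would read in this assay.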